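This account rests on a few compounds, and the source may have more. Where it says the series, first, only, none or still open, it means among the compounds named here.

- compound 1 `CCCCc1ccc2[nH]c(-c3ccc(OC)cc3)c(/C=N/O)c2c1` gives 40 nM
- compound 2 `CCCCc1ccc2[nH]c(-c3ccc(OC)cc3)c(/C=N/NC(=O)c3cccc(OC)c3)c2c1` gives 55 nM
- compound 3 `CCCCc1ccc2[nH]c(-c3ccc(OC)cc3)c(/C=N/NC(=O)c3ccc([N+](=O)[O-])cc3)c2c1` gives 115 nM

All three values come from a functional assay on MDA-MB-231 cells (Homo sapiens) for antiproliferative activity, with a stated time of 4 days (a higher number here means a weaker inhibitor, a lower number a stronger inhibitor), and, among them, compound 3 has the highest number and is the weakest inhibitor. Compound 4 `CCCCc1ccc2[nH]c(-c3ccc(OC)cc3)c(/C=N/NC(=O)c3ccccn3)c2c1` differs from compound 3 in one place (pyridin-2-yl in place of 4-nitrophenyl on a carbonyl carbon). The closest evidence is the measured change at that same carbonyl carbon, a 2.1-fold higher number from compound 2 to compound 3 (0.32 log units; beyond the scatter), a modest step on replacing 3-methoxyphenyl with 4-nitrophenyl. The other measured change, a 1.4-fold higher number from compound 1 to compound 2 (0.14 log units; within the scatter), lies further out and is less direct. Among the measured compounds shown here, no compound measured so far carries pyridin-2-yl, so the direction is tentative. A modest move back towards a lower number is expected, since compound 3 at 115 nM stands apart from compound 2 at 55 nM in this series. The expected change is a 1.6-fold lower number from compound 3 to compound 4 (0.22 log units; within the scatter) in this assay. For compound 4 the estimate is 70 nM, with an expected range from 30 nM to 170 nM as its bounds.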

Compound 4, half-maximal inhibitory concentration: 34 nM
For compound 4 the middle estimate is 2.1-fold (0.31 log units) above the measured one; measured number inside the range.
By their numbers in this assay, from the lowest: compounds 4, 1 and 2 (each within the scatter of the next); then compound 3.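

In this assay, pyridin-2-yl on the carbonyl carbon gives a 3.4-fold lower number from compound 3 to compound 4 (0.53 log units; beyond the scatter) and thereby shows that a change of group at this place can lower the number beyond the scatter, where the earlier change there had only raised it. Set against the other two compounds, a 1.6-fold lower number from compound 2 to compound 4 (0.21 log units; within the scatter) and a 1.2-fold lower number from compound 1 to compound 4 (0.07 log units; within the scatter) leave no readable difference, so among the four only the compound with 4-nitrophenyl stands apart. No measurement here accounts for the difference between 4-nitrophenyl and pyridin-2-yl.

From the compounds shown here alone, whether plain phenyl or pyridin-3-yl on this carbonyl carbon would give the same number as pyridin-2-yl stays open. So does the effect of a non-aromatic group there, such as a dimethylamino group or a butyl chain.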